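Swapping the aryl halide in a cinnamate series

This account rests on a few compounds, and the source may have more. Where it says the series, first, only, none or still open, it means among the compounds named here.

Measured compounds:
compound 1, `COc1cc(OC)c(OC)cc1/C=C/COC(=O)/C=C/c1ccccc1C(F)(F)F`, 100%
compound 2, `COc1cc(OC)c(OC)cc1/C=C/COC(=O)/C=C/c1ccccc1Cl`, 100%

In a functional assay on the whole organism (strain Kunming) with Mus musculus as the target, with a stated time of 0.5 h, at a dose of 100 mg/kg by the intraperitoneal route (a lower number here means a stronger effect, a higher number a weaker effect of the compound at the dose given), compound 1 gives 100%. Within the data shown here, compound 2 stands level with compound 1, and the only step measured so far, no change at the digits printed from compound 1 to compound 2 (within the scatter), lies within the scatter. Compound 3, `COc1cc(OC)c(OC)cc1/C=C/COC(=O)/C=C/c1ccc(F)cc1`, has not been measured. It differs from compound 2 by 4-fluorophenyl in place of 2-chlorophenyl on a double-bonded chain carbon bound to a double-bonded chain carbon. Among the measured compounds shown here, no measured step covers a move of the halogen to another ring position, so the one step available, which showed no change, is the only guide. A step of a number 5 percentage points lower from compound 2 to compound 3 (within the scatter) is expected, that is little or no change beyond the scatter. For compound 3 the estimate is 95%, ranging from 75% to 100%.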

Compound 3, a percentage reported as activity, at one dose (the size of the read-out at that dose, not a potency): 100%
The estimate for compound 3 lay 5 percentage points below the measured number; measured number inside the range.
By their numbers in this assay, from the lowest: compounds 1, 2 and 3 (each within the scatter of the next).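

In this assay, 4-fluorophenyl in place of 2-chlorophenyl gives no change at the digits printed from compound 2 to compound 3 (within the scatter), and 4-fluorophenyl in place of 2-(trifluoromethyl)phenyl gives no change at the digits printed from compound 1 to compound 3 (within the scatter). The earlier pair differed only in the group on the same ring carbon, whereas these steps change both the halogen and where it sits on the ring. Even so, the read-out stays level across all three compounds.

As far as these compounds go, whether an amine or a carboxylic acid on this ring would shift the read-out remains open. No measurement at hand offers an explanation for this level result.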